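The compounds below may be only part of what the source reports. "The series", "measured", "known", "first", "only" and "open" are said of these compounds alone.

Compound 2 `CN(C)c1ccc(C2SCC(=O)N2NC(=O)CN2C(=O)c3ccccc3C2=O)cc1` gives the higher of the two numbers in a physicochemical assay for lipophilicity, in phosphate buffer, measured as octanol-water partition, with a stated time of 24 h (on this read-out lower numbers stand for lower lipophilicity and higher numbers for higher lipophilicity), at 2.84; compound 1 `O=C(CN1C(=O)c2ccccc2C1=O)NN1C(=O)CSC1c1ccccc1` gives 2.23, and the step of a number 0.61 log units higher from compound 1 to compound 2 (beyond the scatter) lies beyond the scatter. Compound 3 `O=C(CN1C(=O)c2ccccc2C1=O)NN1C(=O)CSC1c1c[nH]c2ccccc12` differs from compound 2 by 1H-indol-3-yl in place of 4-(dimethylamino)phenyl on a saturated ring carbon. For the measured compounds named here, no measured step covers this exchange; the only step known, a number 0.61 log units higher from compound 1 to compound 2 (beyond the scatter), concerns a different group at the same place and cannot fix the direction here. The step of a number 0.34 log units lower from compound 2 to compound 3 (beyond the scatter) is therefore expected to be small, with a modest fall from compound 2 more likely than a rise. Compound 3 is estimated at 2.5, within 2 to 3.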

Compound 3, partition coefficient: 1.59
Beside the measured number, compound 3's estimate is 0.91 log units above it; measured number below the stated range.
By their numbers in this assay, from the lowest: compound 3; then compound 1; then compound 2.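

In this assay, this saturated ring carbon now reads in both directions: the step of a number 1.25 log units lower from compound 2 to compound 3 (beyond the scatter) is large, and the step of a number 0.64 log units lower from compound 1 to compound 3 (beyond the scatter) takes the number under that of the phenyl compound. The two exchanged groups in the first step match in heavy atoms and carry no net charge, but differ in hydrogen-bond donors and acceptors and in ring make-up. No measurement on hand accounts for the fall. Open, going by these compounds, is whether an indole with a methyl group on its nitrogen would give a similar number. On these data alone, a carboxylic acid on the phenyl ring also remains open.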